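The compounds below may be only part of what the source reports. "The series", "measured", "known", "first", "only" and "open" are said of these compounds alone.

Measured compounds:

Compound 1, `Cc1n[nH]c2c1C(c1ccc(N(C)C)cc1)C(C(N)=O)=C(N)N2`: 4550 nM
Compound 2, `Cc1n[nH]c2c1C(c1ccc(N(C)C)cc1)C(C(=O)NNC(N)=S)=C(N)N2`: 5210 nM
Compound 3, `Cc1n[nH]c2c1C(c1ccc(N(C)C)cc1)C(C(=O)NNc1cc([N+](=O)[O-])ccc1[N+](=O)[O-])=C(N)N2`: 13000 nM

All three were tested in a functional assay on MCF7 cells (Homo sapiens) for cytotoxicity, read by MTT assay, with a stated time of 48 h; on this read-out higher numbers stand for weaker inhibition and lower numbers for stronger inhibition. Among them, compound 2 stands second highest of the three numbers; its nearest neighbour is compound 1, with a 1.1-fold higher number from compound 1 to compound 2 (0.06 log units; within the scatter), and its furthest is compound 3, with a 2.5-fold higher number from compound 2 to compound 3 (0.40 log units; beyond the scatter).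

The unmeasured compound 4, `Cc1n[nH]c2c1C(c1ccc(N(C)C)cc1)C(C(=O)n1ncc(C#N)c1N)=C(N)N2`, differs from compound 2 by a group of 8 heavy atoms (4 carbon, 4 nitrogen; one five-membered aromatic ring with 2 hetero atoms) in place of a group of 5 heavy atoms (1 carbon, 3 nitrogen, 1 sulfur; no ring), on a carbonyl carbon, a 5-amino-4-cyano-1H-pyrazol-1-yl group on the carbonyl carbon where compound 2 carries the thiosemicarbazide-type chain.

Among the compounds with values here, two measured steps bear on this region. The step from compound 1 to compound 2, which built up that chain, stayed within the scatter. The step from compound 2 to compound 3, which put a larger aromatic group onto this chain, gave a modest rise in the number. Compound 4 exchanges the chain for a smaller heteroaromatic ring attached directly to the carbonyl carbon, so a small weakening at most is expected in this assay, with a 1.2-fold higher number from compound 2 to compound 4 (0.10 log units; within the scatter) being the estimated step.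

Compound 4 is therefore expected to give about 6500 nM in this assay, within a range of 3000 nM to 14000 nM.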

Compound 4, half-maximal inhibitory concentration: 62700 nM
Beside the measured number, compound 4's estimate is 9.6-fold (0.98 log units) below it; measured number above the stated range.
By their numbers in this assay, from the lowest: compounds 1 and 2 (each within the scatter of the next); then compound 3; then compound 4.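

In this assay the change on the carbonyl carbon whose other neighbour is a double-bonded ring carbon gives a 12-fold higher number from compound 2 to compound 4 (1.08 log units; beyond the scatter) when 5-amino-4-cyano-1H-pyrazol-1-yl replaces the thiosemicarbazide-type chain, and a 14-fold higher number from compound 1 to compound 4 (1.14 log units; beyond the scatter) when the same group replaces amino. Both steps are large, whereas the earlier compounds showed only a step within the scatter and a modest rise, so this position is shown for the first time to be able to move the number substantially; size alone does not set the order, since compound 3, with the larger entering group, gives 13000 nM and compound 4, with the smaller one, gives 62700 nM in the same assay. No accompanying measurement accounts for the rise.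

The compounds shown do not separate the pyrazole ring from its amino and nitrile substituents, and it stays open whether an unsubstituted 1H-pyrazol-1-yl group on the same carbonyl carbon would read closer to compound 1 or to compound 4. Also open, on these data alone, is how a carboxylic acid or a simple methylamine amide would read at this position in this assay on the same core.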